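The source may report more compounds than this note shows. Statements on the series, on what has been measured and on what is new or still open speak of the compounds shown alone.

Within the data shown here, in a physicochemical assay for lipophilicity, measured as octanol-water partition, at pH 7.4 (a higher number here means a more lipophilic compound, a lower number a more polar compound), compound 2 (`CC(=O)N(C)c1ccc2c(c1)CCN2c1cc(OC2CCN(c3nc(C(C)C)no3)CC2)ncn1`) gives 3.7 and stands higher of the two compounds measured so far, while compound 1 (`CC(C)c1noc(N2CCC(Oc3cc(N4CCc5cc(N6CCCNS6(=O)=O)ccc54)ncn3)CC2)n1`) gives 3.2 here. Compound 3 (`CC(C)c1noc(N2CCC(Oc3cc(N4CCc5cc(S(C)(=O)=O)ccc54)ncn3)CC2)n1`) carries methylsulfonyl in place of acetyl(methyl)amino on an aromatic carbon and has not yet been measured. Among the measured compounds shown here, one measured step bears on this change: a number 0.50 log units higher from compound 1 to compound 2 (beyond the scatter) is modest, and there acetyl(methyl)amino replaced a larger ring-bearing group that, like methylsulfonyl, holds sulfur. A small fall in this assay is therefore expected (a number 0.20 log units lower from compound 2 to compound 3 (within the scatter)), perhaps not beyond the scatter. Compound 3 is estimated at 3.5 with a likely range from 3.1 to 3.9 in this measurement.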

Compound 3, distribution coefficient: 3.1
Compound 3: the middle estimate sits 0.40 log units above what was measured; the range from low to high includes it.
By their numbers in this assay, from the lowest: compounds 3 and 1 (each within the scatter of the next); then compound 2.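

In this assay, the swap at this aromatic carbon is not neutral: replacing acetyl(methyl)amino with methylsulfonyl gives a number 0.60 log units lower from compound 2 to compound 3 (beyond the scatter) and a step beyond the scatter. The two sulfur-bearing groups cannot be told apart, since a number 0.10 log units lower from compound 1 to compound 3 (within the scatter) stays within the scatter, even though one carries a six-membered ring and the other has no ring. No evidence here explains either step.

Among these compounds, with only three groups at this position, no general trend can be drawn. From the compounds shown here alone, how a simple amine or a carboxylic acid on this carbon would compare remains open.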